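Working notes on a methylsulfonyl-for-methyl swap on the ring nitrogen

The source may report more compounds than this note shows. Statements on the series, on what has been measured and on what is new or still open speak of the compounds shown alone.

Measured compounds:
- compound 1, `CNC(=O)N1CCCc2ccc(NC(=O)c3ccc(-c4cc[nH]n4)cc3)cc21`, in a functional assay on MV4-11 cells (Homo sapiens) for antiproliferative activity, with a stated time of 6 days, tested at 1.56 uM; on this read-out lower numbers stand for a weaker effect and higher numbers for a stronger effect at the one concentration tested: 92.5%
- compound 2, `CNC(=O)N1CCCc2ccc(NC(=O)c3cccc(-c4cnn(C)c4)c3)cc21`, in this assay: 71.2%
- compound 3, `CNC(=O)N1CCCc2ccc(NC(=O)c3ccc(-c4ccn(S(C)(=O)=O)n4)cc3)cc21`, in this assay: 8.81%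

Compound 2 stands second highest of the three numbers; compound 1 lies above it beyond the scatter, and compound 3 lies far below it, also beyond the scatter.

Compound 4, `CNC(=O)N1CCCc2ccc(NC(=O)c3cccc(-c4cnn(S(C)(=O)=O)c4)c3)cc21`, is not yet measured. It differs from compound 2 by methylsulfonyl in place of methyl on an aromatic nitrogen.

Among the measured compounds shown here, one measured step bears on this change: a number 83.7 percentage points lower from compound 1 to compound 3 (beyond the scatter). That step also placed a methylsulfonyl on an aromatic nitrogen, though there it replaced hydrogen rather than methyl, and it was large. In this assay a drop of similar character is therefore expected for compound 4, bounded below by the floor of the read-out. The step from compound 2 to compound 4 is expected to be a number 56.2 percentage points lower from compound 2 to compound 4 (beyond the scatter). The value of compound 4 is estimated at 15%, within a range from 0% to 45%.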

Compound 4, a percentage reported as inhibition, at one concentration (the size of the read-out at that concentration, not a potency): 1.6%
Beside the measured number, compound 4's estimate is 13.4 percentage points above it; the measured number falls inside the stated range.
By their numbers in this assay, from the lowest: compounds 4 and 3 (each within the scatter of the next); then compound 2; then compound 1.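

In this assay, methylsulfonyl in place of methyl on the aromatic nitrogen gives a number 69.6 percentage points lower from compound 2 to compound 4 (beyond the scatter), so the loss seen earlier as a number 83.7 percentage points lower from compound 1 to compound 3 (beyond the scatter) is now seen in a second pair, and neither pair goes against it. The new pair starts from a nitrogen that already carries methyl, in 1-methyl-1H-pyrazol-4-yl, so a large drop does not require a hydrogen on that nitrogen as the starting point. Nothing available accounts for the loss.

Open, as far as these compounds go, is whether the sulfonyl unit itself or simply a larger group on this nitrogen goes with the loss, which an acetyl or ethyl group there would help separate. Also open, from the compounds shown here alone, is how a basic chain such as 2-aminoethyl on the same nitrogen would read out.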